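Swapping fluoro for hydrogen on compound 3

The source may report more compounds than this note shows. Statements on the series, on what has been measured and on what is new or still open speak of the compounds shown alone.

Compound 1 `C=CC(=O)N1CCC(Oc2nc(Nc3ccc(N(C)CCN(C)C)cc3OC)nc3[nH]ccc23)CC1` gives > 20000 nM, a limit
Compound 2 `C=CC(=O)N1CCC(Oc2nc(Nc3ccc(N4CCN(C)CC4)cc3OC)nc3[nH]ccc23)CC1` gives > 20000 nM, a limit
Compound 3 `C=CC(=O)N1CCC(Oc2nc(Nc3ccc(N4CCN(C)CC4)c(F)c3)nc3[nH]ccc23)CC1` gives 3020 nM

All three compounds were tested in a toxicity assay on cells (Epithelial cell, Homo sapiens) for cytotoxicity, read by MTT assay, with a stated time of 72 h; on this read-out lower numbers stand for stronger inhibition and higher numbers for weaker inhibition. Compound 1 and compound 2 both stand at the limit of > 20000 nM in this assay, at which 2 of the 3 values shown sit, so neither offers a true number. Going by the values given here, compound 3, at 3020 nM, holds the only number in the set.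

The next compound is compound 4 `C=CC(=O)N1CCC(Oc2nc(Nc3ccc(N4CCN(C)CC4)cc3)nc3[nH]ccc23)CC1`, which has not yet been measured. It differs from compound 3 by one exchange: hydrogen in place of fluoro on an aromatic carbon. In words, hydrogen takes the place of fluoro on an aromatic carbon ortho to a 4-methylpiperazin-1-yl group.

Among the compounds with values here, the single measured step, a step that the two limits leave unreadable from compound 1 to compound 2, concerns a different group, and its size cannot be read. Within the data shown here, no measured step touches the fluoro, so the data give no direction for this exchange, and no change beyond the scatter is expected in this assay. The expectation is anchored on compound 3 at 3020 nM and stays wide. A limit remains possible for compound 4. The expected change is a 1.3-fold higher number from compound 3 to compound 4 (0.12 log units; within the scatter). For compound 4 the estimated value is 4000 nM, with an expected range from 1500 nM to 12000 nM.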

Compound 4, half-maximal inhibitory concentration: 7940 nM
The estimate for compound 4 lay 2.0-fold (0.30 log units) below the measured number; the range from low to high includes it.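

In this assay, going by these compounds alone, the exchange of hydrogen for fluoro on the aromatic carbon ortho to a 4-methylpiperazin-1-yl group gives a 2.6-fold higher number from compound 3 to compound 4 (0.42 log units; beyond the scatter) and thereby supplies the first readable step in the set, showing that what sits on this carbon changes the number beyond the scatter. Hydrogen in place of methoxy on an aromatic carbon is a separate exchange, and it gives an at least 2.5-fold lower number from compound 2 to compound 4 (0.40 log units; beyond the scatter) as a second step beyond the scatter, so compound 4 connects both compound 2 and compound 3 to one reference. The size of that second step remains a lower bound only, because compound 2 stands at a limit: the limit of > 20000 nM in this assay, at which 2 of the 4 values shown sit.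

Only fluoro and hydrogen are shown on the carbon ortho to the 4-methylpiperazin-1-yl group, so it remains open whether chloro, methyl or a nitrile there would move the number further in either direction. Going by these compounds, it is also open whether fluoro would give a step of similar size in a compound carrying the (2-(dimethylamino)ethyl)(methyl)amino group of compound 1 in place of the 4-methylpiperazin-1-yl group.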